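A few compounds are considered here, and "the series" means these few. Any claim that something is new, unique, unknown or untested is made for them only; others in the source may bear on it.

Measured in an ADME assay on MRC5 cells (Homo sapiens) for cytotoxicity, read by fluorescence and resazurin assay, with a stated time of 24 h; a higher number here means a weaker inhibitor, a lower number a stronger inhibitor:
compound 1 `CCOC(=O)c1c(-c2ccccc2)oc2nc(N3CCCC3)ccc12`: > 297000 nM (a limit)
compound 2 `CCOC(=O)c1c(C)oc2ncc(N3CCCC3)cc12`: > 364000 nM (a limit)

Compound 2 has no exact number in this assay: its > 364000 nM is a limit. The only other result available, for compound 1, is also a limit, so no ranking of the two can be drawn.

Compound 3 `CCOC(=O)c1c(-c2ccccc2)oc2ncc(N3CCCC3)cc12` has not yet been measured. It is compound 2 with a single change: phenyl in place of methyl on an aromatic carbon. Phenyl takes the place of methyl on an aromatic carbon, next to the ring oxygen and next to the ring atom that bears an ethoxycarbonyl group.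

Going by the values given here, no measured pair isolates this change, so its effect cannot be read directly. The expectation of no step beyond the usual scatter in this assay rests on compound 1, which also carries phenyl and gives the limit > 297000 nM. The expected size of the change is an at least 1.2-fold lower number from compound 2 to compound 3 (0.08 log units; that floor lies within the scatter). For compound 3 the estimated value is 297000 nM, with an expected range from 150000 nM to 400000 nM.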

Compound 3, half-maximal inhibitory concentration: > 297000 nM
Compound 3: a limit, no number; the forecaster's own chance of this, stated with the estimate: 85%; the middle value lies on the limit itself.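

Going by these compounds alone, compound 2 and compound 3 each have only a limit in this assay, not a number, so no step between them can be read. The compounds shown leave open whether phenyl in place of methyl on an aromatic carbon changes the result at all, and at what concentration any of the three compounds would reach half-maximal inhibition.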